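The source may report more compounds than this note shows. Statements on the series, on what has been measured and on what is new or still open speak of the compounds shown alone.

Measured so far:
- compound 1 `Oc1ccc(CNc2cc(Br)cc3[nH]ncc23)cc1Cl` — 60%
- compound 2 `Brc1cc(NCc2cccc3nonc23)c2cn[nH]c2c1` — 91%
- compound 3 `CCOC(=O)Nc1cccc(CNc2cc(Br)cc3[nH]ncc23)c1` — 29%

All three share the core of compound 1 and were run in an assay for inhibition of Indoleamine 2,3-dioxygenase 1 (Homo sapiens), with a stated time of 1 h, tested at 10 uM; on this read-out higher numbers stand for more inhibition at the one concentration tested (going by the name of the read-out) and lower numbers for less inhibition. Compound 3 stands lowest of the three numbers: compound 1 sits a step above it that lies beyond the scatter, and compound 2 sits further above, also beyond the scatter. No pair of these compounds differs in a single place, so the numbers are read side by side only, without a counted step between any two of them.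

The next compound, compound 4 `OC1CCCC(Nc2cccc(CNc3cc(Br)cc4[nH]ncc34)c2)C1`, differs from compound 3 in one place: 3-hydroxycyclohexyl in place of ethoxycarbonyl on a nitrogen on an aromatic ring. Among the compounds with values here, nothing among the measured compounds carries the entering group, so no measured step speaks to this change directly. Compound 1, which carries a hydroxyl on its aromatic ring, gives 60%, and compound 3 gives 29%; on that thin basis a rise for compound 4 is plausible but not assured.

For compound 4 the expected step in this assay is a number 13 percentage points higher from compound 3 to compound 4 (beyond the scatter), a modest rise that may or may not clear the scatter. Compound 4 is estimated at 42%, with a range from 15% to 70%.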

Compound 4, a percentage reported as inhibition, at one concentration (the size of the read-out at that concentration, not a potency): 52%
The estimate for compound 4 lay 10 percentage points below the measured number; the measured number falls inside the stated range.
By their numbers in this assay, from the lowest: compound 3; then compounds 4 and 1 (each within the scatter of the next); then compound 2.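

In this assay, within the data shown here, the substituent on the nitrogen on an aromatic ring can change the read-out: 3-hydroxycyclohexyl in place of ethoxycarbonyl gives a number 23 percentage points higher from compound 3 to compound 4 (beyond the scatter), the first step between two compounds that differ in one place. This position therefore accepts a group of 7 heavy atoms with a six-membered non-aromatic ring of carbon only, with no loss of inhibition, and the double bond outside aromatic rings in ethoxycarbonyl is not required for the number reached by compound 4. The change alters the ring, the double bond and the hydrogen-bond donor count together, and no measurement here separates these changes or bears on why the number moves.

Still open, as far as these compounds go, is which part of the entering group goes with the step: plain cyclohexyl would test the ring without the hydroxyl, and a straight hydroxyalkyl chain would test the hydroxyl without the ring. An amine or a carboxylic acid on the cyclohexyl ring in place of the hydroxyl would show whether this position accepts other groups on that ring.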